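The source may report more compounds than this note shows. Statements on the series, on what has been measured and on what is new or still open speak of the compounds shown alone.

Measured in a functional assay on MCF7 cells (Homo sapiens) for cytotoxicity, read by ELISA, with a stated time of 4 days; a lower number here means a stronger inhibitor, a higher number a weaker inhibitor:
- compound 1 `Cc1ccsc1-c1cc(-c2ccoc2)cc(-c2ccco2)n1`: 18300 nM
- compound 2 `Cc1ccsc1-c1cc(-c2ccc(Cl)o2)cc(-c2ccco2)n1`: 5570 nM

Among the measured compounds shown here, compound 2 holds the lower of the two numbers so far. The next compound, compound 3 `Cc1ccsc1-c1cc(-c2ccc(Cl)o2)cc(-c2cccnc2)n1`, carries pyridin-3-yl in place of furan-2-yl on an aromatic carbon, next to the ring nitrogen (pyridin-3-yl in place of furan-2-yl on an aromatic carbon). For the measured compounds named here, only one measured step exists, a 3.3-fold lower number from compound 1 to compound 2 (0.52 log units; beyond the scatter), which is modest and beyond the scatter. That step exchanged furan-3-yl for 5-chlorofuran-2-yl and left furan-2-yl untouched, so it bears on compound 3 only indirectly, as a guide to size. Going by the values given here, no measurement yet covers a change at the furan-2-yl position, so no firm direction can be set in this assay, and no step beyond the scatter is expected. The expected step is a 1.2-fold higher number from compound 2 to compound 3 (0.07 log units; within the scatter). For compound 3 the estimated value is 6500 nM, with an expected range of 2200 nM to 19000 nM.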

Compound 3, half-maximal inhibitory concentration: 5810 nM
Estimate against measurement, compound 3: 1.1-fold (0.05 log units) above; low and high end bracket the measured number.
By their numbers in this assay, from the lowest: compounds 2 and 3 (each within the scatter of the next); then compound 1.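

The position on an aromatic carbon next to the ring nitrogen, which held furan-2-yl in both earlier compounds, now has a measured exchange: in this assay, pyridin-3-yl for furan-2-yl gives a 1.0-fold higher number from compound 2 to compound 3 (0.02 log units; within the scatter), within the scatter. A five-membered aromatic ring with one oxygen and a six-membered aromatic ring with one nitrogen are therefore not told apart here, at least with 5-chlorofuran-2-yl in the other position. The only step beyond the scatter among the compounds shown remains the one at the position carrying that chlorofuran, so this position has not yet moved the number. No measured property is available to account for this result.

Open, as far as these compounds go, is whether this position stays as indifferent to a group of a different kind, such as a carboxylic acid, a primary amine or a longer alkyl chain. Also open, from the compounds shown here alone, is whether pyridin-3-yl gives the same outcome with furan-3-yl in place of 5-chlorofuran-2-yl.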